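Swapping 4-methylphenyl for 2-hydroxyphenyl on a sulfonyl sulfur

A few compounds are considered here, and "the series" means these few. Any claim that something is new, unique, unknown or untested is made for them only; others in the source may bear on it.

In an ADME assay on HEK293 cells (Homo sapiens) for cytotoxicity, read by resazurin assay, with a stated time of 48 h (on this read-out lower numbers stand for higher toxicity in this test and higher numbers for lower toxicity in this test), compound 1 (`Cc1ccc(S(=O)(=O)Nc2ccc(-c3nc4ccccc4o3)cc2)cc1`) gives 88000 nM and compound 2 (`O=S(=O)(Nc1ccc2oc(-c3ccccc3)nc2c1)c1ccccc1F`) gives 72000 nM, two numbers within the scatter of each other. Compound 3 (`O=S(=O)(Nc1ccc2oc(-c3ccccc3)nc2c1)c1cccc(O)c1`) yields no number, only a limit of the assay, > 100000 nM.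

Compound 4 (`O=S(=O)(Nc1ccc(-c2nc3ccccc3o2)cc1)c1ccccc1O`) keeps the core of compound 1 and carries 2-hydroxyphenyl in place of 4-methylphenyl on a sulfonyl sulfur. Among the measured compounds shown here, one measured step bears on this change, as it also brings a hydroxyphenyl group onto the sulfonyl sulfur: an at least 1.3-fold higher number from compound 2 to compound 3 (0.14 log units; that floor lies within the scatter). Its floor lies within the scatter, but it starts from a fluorophenyl group on a different core, so it is only indirect guidance.

No step beyond the scatter is therefore expected in this assay. The expected change is a 1.0-fold higher number from compound 1 to compound 4 (0.01 log units; within the scatter). For compound 4 the estimated value is 90000 nM, with an expected range of 50000 nM to 160000 nM.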

Compound 4, half-maximal cytotoxic concentration: > 100000 nM
Compound 4 gave a limit, no number; the forecaster's own chance of this, stated with the estimate: 45%; middle value at least 1.1-fold (0.04 log units) from the limit.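

In this assay compound 4 gives only a limit of the assay, > 100000 nM, not a number. The change can now be read on the core of compound 1 itself rather than through a step on a different core: 2-hydroxyphenyl in place of 4-methylphenyl on a sulfonyl sulfur gives an at least 1.1-fold higher number from compound 1 to compound 4 (0.05 log units; that floor lies within the scatter). The step shows no move towards a lower number, but its true size stays unknown because of a limit shared with another compound: the limit of > 100000 nM in this assay, at which 2 of the 4 values shown sit.

As far as these compounds go, it remains open whether 3-hydroxyphenyl on the core of compound 1 would behave as 2-hydroxyphenyl does here. From the compounds shown here alone, it is also open whether an amine or a carboxylic acid on that phenyl ring, in place of the hydroxyl, would bring the read-out down to a measurable number.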